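Furan to Methylthiophene: Expecting a Modest Gain

The source may report more compounds than this note shows. Statements on the series, on what has been measured and on what is new or still open speak of the compounds shown alone.

Compound 1 `COc1ccc(OC)c(C(=O)/C=C/c2ccco2)c1` carries a furan-2-yl group on the chain. Going by the values given here, in a functional assay on A549 cells (Homo sapiens) for cytotoxicity, read by MTT assay (on this read-out lower numbers stand for stronger inhibition and higher numbers for weaker inhibition), compound 1 gives 27900 nM, the highest of the two numbers measured so far. Its nearest neighbour is compound 2 `COc1ccc(OC)c(C(=O)/C=C/c2cccs2)c1`, which in this assay gives 11000 nM. Among the compounds with values here, that pair defines the only step seen so far: a 2.5-fold lower number from compound 1 to compound 2 (0.40 log units; beyond the scatter), a modest change that nonetheless lies beyond the scatter.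

Compound 3 `COc1ccc(OC)c(C(=O)/C=C/c2sccc2C)c1` has not yet been measured. Relative to compound 1 it differs in one place: 3-methylthiophen-2-yl in place of furan-2-yl on a double-bonded chain carbon bound to a double-bonded chain carbon. The step of a 2.5-fold lower number from compound 1 to compound 2 (0.40 log units; beyond the scatter) bears directly on this change, as compound 3 carries the 3-methylthiophen-2-yl group, which differs from the thiophen-2-yl of compound 2 only by its methyl. Nothing in the measured pair shows what that methyl does on its own, so the expectation rests on the thiophene step alone. A step of about the same size and direction as a 2.5-fold lower number from compound 1 to compound 2 (0.40 log units; beyond the scatter) is therefore expected, giving a 3.1-fold lower number from compound 1 to compound 3 (0.49 log units; beyond the scatter). Compound 3 is estimated to give 9000 nM in this assay, within a range from 3500 nM to 25000 nM.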

Compound 3, half-maximal inhibitory concentration: 22200 nM
Compound 3: middle estimate off by 2.5-fold (0.39 log units), on the low side, within the range that was stated.
By their numbers in this assay, from the lowest: compounds 2, 3 and 1 (each within the scatter of the next, the first and the last beyond it).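

The new compound changes how the thiophene step can be read. Swapping furan-2-yl for 3-methylthiophen-2-yl on this double-bonded chain carbon gives a 1.3-fold lower number from compound 1 to compound 3 (0.10 log units; within the scatter) in this assay, so the separation that the plain thiophen-2-yl group achieved over furan-2-yl is not resolved once the methyl is present. The methyl step itself, methyl in place of hydrogen on an aromatic carbon, gives a 2.0-fold higher number from compound 2 to compound 3 (0.30 log units; within the scatter), which means compound 3 cannot be told apart from either neighbour, although compound 1 and compound 2 remain separated from each other, and the effect of the methyl is therefore neither established nor excluded. Nothing available here explains these numbers.

On these data alone, whether chlorine, a methoxy group or an amine in place of that methyl on the thiophene would produce a step beyond the scatter remains open. It is also unknown whether a methyl on the furan-2-yl group of compound 1 would behave as it does on the thiophene, or whether a phenyl or pyridine ring at this chain carbon would give a number outside the range these three compounds span.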